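The compounds below may be only part of what the source reports. "The series", "measured", "known", "first", "only" and "open" are said of these compounds alone.

Measured in a functional assay on A549 cells (Homo sapiens) for antiproliferative activity, read by sulforhodamine B assay, with a stated time of 72 h; on this read-out lower numbers stand for stronger inhibition of growth and higher numbers for weaker inhibition of growth:
- compound 1, `Cc1cc(=O)oc2cc(Sc3cccc(Cl)n3)ccc12`: compound 1 gives 2110 nM.
- compound 2, `CCc1oc2c(C)c(OCc3cccc(C(F)(F)F)c3)ccc2c(=O)c1Br`: compound 2 gives > 22600 nM, which is a limit of the assay and not a number.
- compound 3, `CCc1cc(=O)c2ccc(OC)c(CBr)c2o1`: compound 3 gives > 33600 nM, again a limit of the assay and not a number.

Compound 3 stands at the limit of > 33600 nM in this assay, at which 1 of the 3 values shown sits. Of the three values shown, only compound 1 carries a real number; compound 2 rests at the limit of > 22600 nM in this assay, at which 1 of the 3 values shown sits. Among the measured compounds shown here, no step between measured compounds connects any of them, so the series offers no measured move to lean on.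

Compound 4, `CCOc1ccc2c(=O)cc(CC)oc2c1CBr`, is the next to go into this assay. It differs from compound 3 by methyl in place of hydrogen on a saturated chain carbon bound to an oxygen on an aromatic ring, methoxy to ethoxy. With compound 3 giving no number, nothing anchors the change; the expected step is a step that the limit leaves unreadable from compound 3 to compound 4, none beyond the scatter. Compound 4 is expected to come out near 40000 nM, with a range from 15000 nM to 110000 nM, and most likely reported only as a limit.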

Compound 4, concentration for 50% growth inhibition: > 32100 nM
Compound 4 ended at the assay's limit; the forecaster's own chance of this, stated with the estimate: 75%; the middle value does not contradict the limit.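

Compound 3 and compound 4 both give limits and not numbers, so the change from methoxy to ethoxy yields no readable step. Among the compounds shown here, still open is what that change does to growth inhibition on a measurable scale; only compound 1 carries a real number, and no step links it to the others.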